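The source may hold more compounds than are shown below. What is called first, only, known or untested is meant among the compounds shown, and "the series" means these compounds.

Measured so far:
- compound 1, `Cc1cc(-c2ccc(Cl)cc2)cc(=O)o1`: > 50000 nM
- compound 2, `CCc1cc(C)oc(=O)c1`: > 50000 nM

Compound 1 sits at a limit of a functional assay on K562 cells (Homo sapiens) for inhibition (a lower number here means a stronger inhibitor, a higher number a weaker inhibitor), with the value > 50000 nM given as a limit rather than a number. Compound 2 likewise reaches only a limit in this assay, > 50000 nM; both values sit at the limit of > 50000 nM in this assay, at which 2 of the 2 values shown sit, so nothing is known about how compound 2 ranks. Compound 3, `C#Cc1cc(C)oc(=O)c1`, differs from compound 2 by ethynyl in place of ethyl on an aromatic carbon. Among the measured compounds shown here, no measured pair offers a step to lean on, so no change beyond the scatter is expected; the step from compound 2 to compound 3 is estimated as a step that the limit leaves unreadable from compound 2 to compound 3. Compound 3 is therefore expected to give about 60000 nM, within 20000 nM to 200000 nM, most likely again as a limit.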

Compound 3, half-maximal inhibitory concentration: 2000 nM
Compound 3: the middle estimate sits 30-fold (1.48 log units) above what was measured; measured number outside the range, below it.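

In this assay, ethynyl in place of ethyl opposite the ring oxygen gives an at least 25-fold lower number from compound 2 to compound 3 (1.39 log units; beyond the scatter), so this position responds strongly to the group it carries, although both groups have 2 heavy atoms. The full size of the step cannot be read, as the value for compound 2 is only a limit: the limit of > 50000 nM in this assay, at which 2 of the 3 values shown sit.

The compounds shown leave open whether a vinyl group, a nitrile or a longer alkyne at this position would match ethynyl. They also leave open how far the methyl group on the shared core matters to compound 3.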